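Moving the Methylpyrazole Attachment Point in a Cold-Receptor Agonist

The compounds below may be only part of what the source reports. "The series", "measured", "known", "first", "only" and "open" are said of these compounds alone.

Compound 1 `Cc1ccc(OCC(=O)N(Cc2cccs2)c2ccnn2C)cc1` was tested in an assay on HEK293 cells for agonist activity at transient receptor potential cation channel subfamily M member 8 (Homo sapiens), read by fluorescence and calcium flux, with a stated time of 15 min (on this read-out lower numbers stand for an effect already at smaller amounts and higher numbers for an effect only at larger amounts of compound), where compound 1 gives 422 nM. Compound 2 `CCN(Cc1cccs1)C(=O)C(C)(C)Oc1ccc(C)cc1` is a relative that differs in several places at once; in this assay compound 2 gives 11000 nM, so compound 1 carries the lower of the two numbers and acts at smaller amounts. Compound 3 `Cc1ccc(OCC(=O)N(Cc2cccs2)c2cnn(C)c2)cc1` has yet to be measured. It keeps every atom of compound 1 and differs only in how they are joined: 1-methyl-1H-pyrazol-4-yl in place of 1-methyl-1H-pyrazol-5-yl on an amide-type nitrogen. The amide-type nitrogen thus still carries a methylpyrazole, but the ring is joined through a different ring atom. For the measured compounds named here, no measured pair shows this particular change, so its size cannot be read off directly. The step of a 2.4-fold higher number from compound 1 to compound 3 (0.37 log units; beyond the scatter) is expected to be a modest loss, somewhat beyond the scatter. Compound 3 is therefore estimated at 1000 nM, with a plausible range from 300 nM to 4000 nM.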

Compound 3, half-maximal effective concentration: 63000 nM
Compound 3: the middle estimate sits 63-fold (1.80 log units) below what was measured; measured number outside the range, above it.
By their numbers in this assay, from the lowest: compound 1; then compound 2; then compound 3.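

In this assay, the way the methylpyrazole is joined to the amide-type nitrogen turns out to matter greatly: swapping 1-methyl-1H-pyrazol-5-yl for 1-methyl-1H-pyrazol-4-yl gives a 150-fold higher number from compound 1 to compound 3 (2.17 log units; beyond the scatter). The two groups have the same heavy atoms and the same counts of hydrogen-bond donors and acceptors, so these counts do not predict the size of this step, and a simple atom tally would not separate compound 1 from compound 3. Nothing available here accounts for why the change of ring atom has so large an effect.

The compounds shown leave open how a 1-methyl-1H-pyrazol-3-yl group would behave on this nitrogen, and whether the unmethylated pyrazole would follow compound 1 or compound 3. They also leave open whether a pyridyl ring could stand in for the methylpyrazole here.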